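The source may hold more compounds than are shown below. What is called first, only, known or untested is meant among the compounds shown, and "the series" means these compounds.

Measured so far in an ADME assay on microsomes from liver (Mus musculus) for metabolic stability (on this read-out higher numbers stand for fast clearance and lower numbers for slow clearance), for the series
Compound 1 `COc1ccc(S(=O)(=O)Nc2ccc(CN3C[C@@H]4C[C@H]3CN4C(=O)c3cccc(Cl)c3)cc2)cc1` gives > 50 mL.min-1.g-1 as a limit of the assay, not a number
Compound 2 `Cc1ccc(S(=O)(=O)Nc2ccc(CN3C[C@@H]4CN(C(=O)c5cccc(Cl)c5)C[C@@H]4C3)cc2)cc1` gives > 50 mL.min-1.g-1 as a limit of the assay, not a number
Compound 3 `COc1ccc(S(=O)(=O)Nc2ccc(CN3CCN(C(=O)C4CN(C(C)=O)C4)CC3)cc2)cc1` gives 1 mL.min-1.g-1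

Going by the values given here, compound 3 at 1 mL.min-1.g-1 is the only compound in this set with a true number, and it lies far from the other two readings. Those readings are limits, as shown by the limit of > 50 mL.min-1.g-1 in this assay, at which 2 of the 3 values shown sit, for compounds 1 and 2. Among the compounds with values here, no measured pair differs in one place only, so the series offers no direct guide to the size of a single change.

Compound 4 `COc1ccc(S(=O)(=O)Nc2ccc(CN3CCN(C(=O)Cn4cccnc4=O)CC3)cc2)cc1` differs from compound 3 in one place. The 1-acetylazetidin-3-yl group leaves and a group with a six-membered aromatic ring with 2 hetero atoms enters, on a carbonyl carbon whose other neighbour is an amide-type nitrogen in a ring a group of 8 heavy atoms (5 carbon, 2 nitrogen, 1 oxygen; one six-membered aromatic ring with 2 hetero atoms) in place of a group of 7 heavy atoms (5 carbon, 1 nitrogen, 1 oxygen; one four-membered non-aromatic ring with 1 hetero atom), on a carbonyl carbon and the rest of the structure stays the same.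

With compound 3 at 1 mL.min-1.g-1 there is more room upward than downward in this assay for this change. The expected step of a 3.0-fold higher number from compound 3 to compound 4 (0.48 log units; beyond the scatter) is therefore a modest rise in clearance, only a little beyond the usual scatter. Compound 4 is estimated at 3 mL.min-1.g-1 with an expected range from 1 mL.min-1.g-1 to 12 mL.min-1.g-1 in this working estimate.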

Compound 4, intrinsic clearance in microsomes in the Mus musculus assay: < 0.5 mL.min-1.g-1
Compound 4 was reported as a limit (the forecaster's own chance of this, stated with the estimate: 10%); middle value at least 6.0-fold (0.77 log units) away from the limit.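

In the Mus musculus assay, the series now has its first readable step at a single place, on a carbonyl carbon whose other neighbour is an amide-type nitrogen in a ring, with compound 4 at < 0.5 mL.min-1.g-1 as a limit of the assay and not a number: an at least 2.0-fold lower number from compound 3 to compound 4 (0.30 log units; that floor lies within the scatter). Replacing the 1-acetylazetidin-3-yl group with a group carrying one six-membered aromatic ring with 2 hetero atoms shows no rise in clearance at this position, but the reading for compound 4 is a limit of the assay and the full size of the step stays hidden: the limit of < 0.5 mL.min-1.g-1 in the Mus musculus assay, at which 1 of the 4 values shown sits. In a physicochemical assay for solubility, measured as kinetic solubility (a higher number here means a more soluble compound, a lower number a less soluble compound), compound 3 gives >= 511000 nM as a limit of the assay and not a number. In the physicochemical assay, compound 4 gives >= 336000 nM as a limit of the assay and not a number. The step between these two readings cannot be read.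

The compounds shown leave open how far clearance lies under the limit for compound 4, and so whether this change has any effect larger than the usual scatter of the assay. Also open, as far as these compounds go, is whether a plain phenyl ring, a carboxylic acid or an aminomethyl group on the same carbonyl carbon would give a similarly low reading in the Mus musculus assay.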